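The source may hold more compounds than are shown below. What is called first, only, known or untested is meant among the compounds shown, and "the series" means these compounds.

Compound 3 `CCCCc1ccc(CN(Cc2ccccc2)C(C)=O)c(=O)n1Cc1ccc(-c2ccccc2-c2nn[nH]n2)cc1` gives the lowest of the three numbers in a functional assay (aorta) for antagonist activity, with Oryctolagus cuniculus as the target (on this read-out lower numbers stand for stronger inhibition and higher numbers for weaker inhibition), at 1 nM. Its nearest neighbour is compound 1 `CCCCc1ccc(CNC(=O)N(C)C)c(=O)n1Cc1ccc(-c2ccccc2-c2nn[nH]n2)cc1`, which in this assay gives 2 nM, a gap that lies within the scatter; the furthest is compound 2 `CCCCc1ccc(CNC(C)=O)c(=O)n1Cc1ccc(-c2ccccc2-c2nn[nH]n2)cc1`, which in this assay gives 3 nM, a gap beyond the scatter.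

Compound 4 `CCCCc1ccc(CN(Cc2ccccc2)S(C)(=O)=O)c(=O)n1Cc1ccc(-c2ccccc2-c2nn[nH]n2)cc1` differs from compound 3 by methylsulfonyl in place of acetyl on an amine nitrogen. Going by the values given here, no measured step changes an acetyl for a methylsulfonyl, but two steps touch the same region. The step of a 1.5-fold higher number from compound 1 to compound 2 (0.18 log units; within the scatter) swaps one carbonyl substituent for another, and the step of a 2.0-fold lower number from compound 1 to compound 3 (0.30 log units; within the scatter) replaces the whole group; both stay within the scatter. Among the compounds with values here, only the step of a 3.0-fold lower number from compound 2 to compound 3 (0.48 log units; beyond the scatter), which adds a benzyl that compound 4 keeps, goes beyond it. Changes at this carbonyl have so far moved this assay little, so compound 4 is expected to shift by a 2.0-fold higher number from compound 3 to compound 4 (0.30 log units; within the scatter), not beyond the scatter. Compound 4 is therefore estimated at 2 nM in this assay, with a range of 0.7 nM to 6 nM.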

Compound 4, half-maximal inhibitory concentration: 2 nM
The estimate for compound 4 equals the measured number at the digits printed; the measured number falls inside the stated range.
By their numbers in this assay, from the lowest: compounds 3, 1, 4 and 2 (each within the scatter of the next, the first and the last beyond it).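

In this assay, the amine nitrogen that carries the benzyl takes methylsulfonyl in place of acetyl with a 2.0-fold higher number from compound 3 to compound 4 (0.30 log units; within the scatter) as the result, so among the compounds shown a carbonyl at this place is not needed to stay in the low range. Measured against the two compounds without the benzyl, the whole benzyl(methylsulfonyl)amino group gives a 1.5-fold lower number from compound 2 to compound 4 (0.18 log units; within the scatter) and no change at the digits printed from compound 1 to compound 4 (within the scatter) as well, which leaves the step from compound 2 to compound 3 as the only one beyond the scatter. Nothing measured here gives a reason for the size of these steps.

As far as these compounds go, it remains open whether an amine or a carboxylic acid on this nitrogen would hold the number in the same range. From the compounds shown here alone, it is equally open whether methylsulfonyl with the amide-type hydrogen in place of the benzyl would behave as compound 2 does.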